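Nitro for bromo on the sulfonyl-linked ring

This account rests on a few compounds, and the source may have more. Where it says the series, first, only, none or still open, it means among the compounds named here.

Compound 1 `CC(O)(C(=O)Nc1ccc(S(=O)(=O)c2ccccc2C#N)cc1)C(F)(F)F` is the only one of the three measured compounds with a number: in a functional assay (Cavia porcellus) with sulfonylurea receptors; K-ATP channels (Homo sapiens) as the target (on this read-out lower numbers stand for stronger inhibition and higher numbers for weaker inhibition), compound 1 gives 1100 nM. Compound 2 `Cc1ccc(S(=O)(=O)c2ccc(NC(=O)C(C)(O)C(F)(F)F)cc2)cc1` reaches only a limit of the assay, > 30000 nM in this assay. Compound 3 `CC(O)(C(=O)Nc1ccc(S(=O)(=O)c2ccc(Br)cc2)cc1)C(F)(F)F` likewise stops at a limit, > 30000 nM in this assay, so compound 3 stands among the two of three values that sit at the limit of > 30000 nM in this assay, at which 2 of the 3 values shown sit. The two steps away from compound 1 are large, an at least 27-fold higher number from compound 1 to compound 2 (1.43 log units; beyond the scatter) and an at least 27-fold higher number from compound 1 to compound 3 (1.43 log units; beyond the scatter), while a step that the two limits leave unreadable from compound 2 to compound 3 cannot be read from two limits.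

Compound 4 `CC(O)(C(=O)Nc1ccc(S(=O)(=O)c2ccc([N+](=O)[O-])cc2)cc1)C(F)(F)F` differs from compound 3 by nitro in place of bromo on an aromatic carbon. For the measured compounds named here, both earlier replacements of 2-cyanophenyl by a ring carrying methyl or bromo ended at the limit, and no measured step tells how nitro behaves; the change from compound 3 to compound 4 is expected to be an at least 1.5-fold lower number from compound 3 to compound 4 (0.17 log units; that floor lies within the scatter). For compound 4 the estimate in this assay is 20000 nM, with a range from 4000 nM to 60000 nM, and a limit is the more likely outcome.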

Compound 4, half-maximal inhibitory concentration: > 30000 nM
Compound 4 was reported as a limit; the forecaster's own chance of this, stated with the estimate: 55%; middle value at least 1.5-fold (0.17 log units) from the limit.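

In this assay compound 4 gives > 30000 nM, which is a limit of the assay and not a number. With 4-nitrophenyl in place of 2-cyanophenyl the result is an at least 27-fold higher number from compound 1 to compound 4 (1.43 log units; beyond the scatter), so a third group at the para place of the ring, and the first of its kind with more than one heavy atom, also fails to give a number. The steps among compound 2, compound 3 and compound 4 cannot be read, and compound 1 remains the only compound with a number: the limit of > 30000 nM in this assay, at which 3 of the 4 values shown sit.

The compounds shown leave open whether the number of compound 1 belongs to the nitrile itself or to where it sits on the ring. They also leave open how far beyond the limit these three compounds lie, and how an amine or a carboxylic acid in place of the nitro would read.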